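The source may hold more compounds than are shown below. What is called first, only, known or untested is meant among the compounds shown, and "the series" means these compounds.

Measured compounds in a functional assay on B16-F10 cells (Mus musculus) for inhibition, read by MTT assay, with a stated time of 48 h; on this read-out higher numbers stand for weaker inhibition and lower numbers for stronger inhibition:
compound 1 `COc1ccc(/C=C/c2cc(OC)cc(OC)c2/C=C/C(=O)N2CCN(C)CC2)cc1` gives 5670 nM;
compound 2 `COc1ccc(/C=C/c2cc(OC)cc(OC)c2/C=C/C(=O)N2CCCCC2C)cc1` gives 7660 nM;
compound 3 `COc1ccc(/C=C/c2cc(OC)cc(OC)c2/C=C/C(=O)N2CCC(c3ccccc3)CC2)cc1` gives 9180 nM.

Compound 2 holds the second highest of the three numbers; its nearest neighbour is compound 3 and its furthest is compound 1, both within the scatter of it. Compound 4 `COc1ccc(/C=C/c2cc(OC)cc(OC)c2/C=C/C(=O)N2CCCC(C)C2)cc1` differs from compound 2 by 3-methylpiperidin-1-yl in place of 2-methylpiperidin-1-yl on a carbonyl carbon. Within the data shown here, two measured steps bear on this change, both altering the group on the carbonyl carbon: a 1.4-fold higher number from compound 1 to compound 2 (0.13 log units; within the scatter) and a 1.2-fold higher number from compound 2 to compound 3 (0.08 log units; within the scatter). Neither reaches beyond the scatter, so no step beyond the scatter is expected in this assay, in either direction. Compound 4 is therefore estimated at 7500 nM, with a range from 3500 nM to 16000 nM. The expected step is a 1.0-fold lower number from compound 2 to compound 4 (0.01 log units; within the scatter).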

Compound 4, half-maximal inhibitory concentration: 8250 nM
Compound 4: the middle estimate sits 1.1-fold (0.04 log units) below what was measured, and the stated range covers the measured number.
By their numbers in this assay, from the lowest: compounds 1, 2, 4 and 3 (each within the scatter of the next).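

In this assay, exchanging 2-methylpiperidin-1-yl for 3-methylpiperidin-1-yl on a carbonyl carbon, with the same atoms joined differently, gives a 1.1-fold higher number from compound 2 to compound 4 (0.03 log units; within the scatter); the location of the methyl group on this ring therefore has no readable effect here. The other new comparisons, a 1.1-fold lower number from compound 3 to compound 4 (0.05 log units; within the scatter) and a 1.5-fold higher number from compound 1 to compound 4 (0.16 log units; within the scatter), leave all four groups on this carbonyl carbon unseparated. No supporting evidence bears on this result. Still open, from the compounds shown here alone, is whether an open-chain diethylamino group, or a piperidin-1-yl group carrying a carboxylic acid, would give a step beyond the scatter.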